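This account rests on a few compounds, and the source may have more. Where it says the series, first, only, none or still open, it means among the compounds named here.

Working notes on the series. Compound 1 `COc1ccc2ncc(-c3nn[nH]n3)cc2c1` is the starting point here. In a functional assay on the whole organism (strain Sprague-Dawley) for inhibition, with Rattus norvegicus as the target (on this read-out higher numbers stand for an effect only at larger amounts of compound and lower numbers for an effect already at smaller amounts), compound 1 returns only a limit, > 25 mg/kg, so no number is known for it. Among the measured compounds shown here, compound 2 `Cc1ccc2cc(C(=O)O)cnc2c1C` gives 50 mg/kg in this assay, and compound 3 `CC(C)Oc1cccc2c(=O)c(-c3nn[nH]n3)c[nH]c12` gives 1.25 mg/kg; both sit on different cores from compound 1, and no single-point step connects any of the three. Where compound 1 stands is therefore fixed only by the limit of > 25 mg/kg in this assay, at which 1 of the 3 values shown sits.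

Compound 4 `c1cc2ncc(-c3nn[nH]n3)cc2cc1OC1CCCCC1` keeps the core of compound 1 and carries the change (cyclohexyl in place of methyl on an oxygen on an aromatic ring). For the measured compounds named here, no measured pair shows the effect of this change, so the size of the step is open. Compound 3, on a different core, is active at 1.25 mg/kg, and that is the only pointer towards a smaller dose in this set. The step from compound 1 to compound 4 is expected to run towards lower doses, an at least 2.0-fold lower number from compound 1 to compound 4 (0.30 log units; that floor lies within the scatter), with a real chance that compound 4 again returns only a limit. Compound 4 is estimated at 12.5 mg/kg, within 3 mg/kg to 50 mg/kg.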

Compound 4, minimum effective dose: 10 mg/kg
The estimate for compound 4 lay 1.3-fold (0.10 log units) above the measured number; the range from low to high includes it.
By their numbers in this assay, from the lowest: compound 3; then compound 4; then compound 2.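

Among the compounds shown here, on the oxygen on an aromatic ring of the shared core, the change from methoxy to cyclohexyloxy gives an at least 2.5-fold lower number from compound 1 to compound 4 (0.39 log units; beyond the scatter) in this assay, the first step that can be read. This position therefore carries cyclohexyl, a six-membered ring of carbon only, and still gives a measured dose, with compound 4 at 10 mg/kg. The step marks only a floor on the change, because compound 1 returns a limit and not a number: the limit of > 25 mg/kg in this assay, at which 1 of the 4 values shown sits.

Isopropoxy, a longer chain or a cyclohexyl bearing an amine on this oxygen remain open, so the compounds shown cannot tell whether the ring itself or the carbon count goes with the lower dose. On these data alone, how compound 4 compares with compound 2 and compound 3 also stays open, as both sit on other cores.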